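A Dimethylamino Group Replaces Chloro

The source may report more compounds than this note shows. Statements on the series, on what has been measured and on what is new or still open speak of the compounds shown alone.

Measured in a physicochemical assay for lipophilicity; a lower number here means a more polar compound, a higher number a more lipophilic compound:
- Compound 1 `O=C1/C(=C/c2ccc(F)cc2)CCC/C1=C\c1cccc([N+](=O)[O-])c1`: 5.07
- Compound 2 `O=C1/C(=C/c2ccc(Cl)cc2)CCC/C1=C\c1cccc([N+](=O)[O-])c1`: 5.58

Compound 2 holds the higher of these two numbers, at 5.58. Compound 3 `CN(C)c1ccc(/C=C2\CCC/C(=C\c3cccc([N+](=O)[O-])c3)C2=O)cc1` has not been measured yet. It keeps the shared core of compound 2 and differs in one place: dimethylamino in place of chloro on an aromatic carbon. In short, dimethylamino stands in place of chloro on an aromatic carbon. Within the data shown here, only one measured step bears on this: a number 0.51 log units higher from compound 1 to compound 2 (beyond the scatter). That step also swaps one group on an aromatic carbon, but neither of its compounds carries dimethylamino, so it guides the size only loosely. With chloro leaving the higher compound, a drop of similar size in this assay is expected, though the direction is uncertain. The expected change is a number 0.43 log units lower from compound 2 to compound 3 (beyond the scatter). For compound 3 the estimate is 5.15, with an expected range from 4.6 to 5.7.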

Compound 3, partition coefficient: 5
Beside the measured number, compound 3's estimate is 0.15 log units above it; low and high end bracket the measured number.
By their numbers in this assay, from the lowest: compounds 3 and 1 (each within the scatter of the next); then compound 2.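

Dimethylamino, with its 3 heavy atoms in place of the single chlorine, gives a number 0.58 log units lower from compound 2 to compound 3 (beyond the scatter) in this assay, so the larger group does not bring a higher number at this place on the aromatic ring. Set against fluoro, the same group gives a number 0.07 log units lower from compound 1 to compound 3 (within the scatter), which leaves compound 1 and compound 3 indistinguishable here; of the three groups, only chloro stands apart, with its steps to both others beyond the scatter. No measurement shown here offers an explanation for this pattern.

Going by these compounds, it remains open whether a plain amine, a methoxy group or a carboxylic acid at this place would fall with chloro or with the other two groups. On these data alone, whether the same swaps would give similar steps on a different core also remains open.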